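The compounds below may be only part of what the source reports. "The series", "measured", "known", "first", "only" and "open" are said of these compounds alone.

Compound 1, `C=C(C(=O)c1ccc(OC)cc1)C(OC(=O)c1ccccc1)c1ccc([N+](=O)[O-])cc1`, is measured in a functional assay on NB-4 cells (Homo sapiens) for inhibition, read by XTT assay, with a stated time of 48 h (on this read-out lower numbers stand for stronger inhibition and higher numbers for weaker inhibition), where compound 1 gives 13200 nM. Among the three measured compounds it stands second highest, close to compound 2, `C=C(C(=O)c1ccc(OC)cc1)C(OC(=O)c1ccccc1)c1c(F)c(F)c(F)c(F)c1F`, which gives 12900 nM, with a 1.0-fold lower number from compound 1 to compound 2 (0.01 log units; within the scatter); furthest is compound 3, `C=C(C(=O)c1ccc(OC)cc1)C(C)OC(=O)c1ccccc1`, with 15700 nM, and a 1.2-fold higher number from compound 1 to compound 3 (0.08 log units; within the scatter). Between those two, a 1.2-fold higher number from compound 2 to compound 3 (0.09 log units; within the scatter). Compound 4, `C=C(C(=O)c1ccc(OC)cc1)C(OC(=O)c1ccccc1)c1ccc([N+](=O)[O-])cc1[N+](=O)[O-]`, differs from compound 1 by nitro in place of hydrogen on an aromatic carbon. Among the measured compounds shown here, no measured step alters the nitrophenyl ring itself; the three steps all swap the whole group on the saturated chain carbon and stay within the scatter, so no step beyond the scatter is expected here either. Compound 4 is therefore estimated at 13000 nM, between 6000 nM and 28000 nM, meaning a 1.0-fold lower number from compound 1 to compound 4 (0.01 log units; within the scatter).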

Compound 4, half-maximal inhibitory concentration: 10000 nM
For compound 4 the middle estimate is 1.3-fold (0.11 log units) above the measured one, within the range that was stated.
By their numbers in this assay, from the lowest: compounds 4, 2, 1 and 3 (each within the scatter of the next).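

Among the compounds shown here, this is the first step that alters the nitrophenyl ring itself rather than swapping the whole group. In this assay, nitro in place of hydrogen on an aromatic carbon gives a 1.3-fold lower number from compound 1 to compound 4 (0.12 log units; within the scatter) for a group of three heavy atoms placed ortho to a large group and meta to a nitro group, so this addition moves the number no further than the scatter. Nothing available explains this result. Going by these compounds, whether an amine or a carboxylic acid on this same aromatic carbon would also stay within the scatter remains open.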